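The source may report more compounds than this note shows. Statements on the series, on what has been measured and on what is new or still open speak of the compounds shown alone.

Three compounds of the series have been run in a functional assay on MCF7 cells (Homo sapiens) for inhibition, read by sulforhodamine B assay, with a stated time of 72 h; on this read-out higher numbers stand for weaker inhibition and lower numbers for stronger inhibition. Compound 1 `CC(c1ccc(-c2ccccc2)c(F)c1)c1nnc2n1N=C(c1ccc(C(F)(F)F)cc1)CS2` gives 4300 nM. Compound 3 `Cc1ccc(C2=Nn3c(nnc3C(C)c3ccc(-c4ccccc4)c(F)c3)SC2)cc1` gives 5000 nM; the step of a 1.2-fold higher number from compound 1 to compound 3 (0.07 log units; within the scatter) corresponds to the change (methyl in place of trifluoromethyl on an aromatic carbon). Compound 2 `COc1ccc2cc(C(C)c3nnc4n3N=C(c3ccc(C(F)(F)F)cc3)CS4)ccc2c1` gives 6900 nM in this assay; the difference between the core of compound 2 and the core of compound 1 is not broken down here, and the two values lie within the scatter of each other. Compound 4 `COc1ccc2cc(C(C)c3nnc4n3N=C(c3ccc(C)cc3)CS4)ccc2c1` is not yet measured; it differs from compound 2 by methyl in place of trifluoromethyl on an aromatic carbon, and the two place descriptions agree word for word, so this counts as the same change. Compound 4 is expected to sit close to compound 2, with a step of about a 1.2-fold higher number from compound 2 to compound 4 (0.06 log units; within the scatter), an expectation resting on the step of a 1.2-fold higher number from compound 1 to compound 3 (0.07 log units; within the scatter). The estimate for compound 4 in this assay is 8000 nM, with a range of 4000 nM to 16000 nM.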

Compound 4, half-maximal inhibitory concentration: 11000 nM
Compound 4: middle estimate off by 1.4-fold (0.14 log units), on the low side; measured number inside the range.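

In this assay, methyl in place of trifluoromethyl gives a 1.6-fold higher number from compound 2 to compound 4 (0.20 log units; within the scatter), so this step too is small. Set beside the earlier step, the change reads the same on the two cores: the same change on two cores in this assay, a 1.2-fold higher number (0.07 log units; within the scatter) from compound 1 to compound 3 and a 1.6-fold higher number (0.20 log units; within the scatter) from compound 2 to compound 4, 1.4-fold (0.14 log units) apart, within the scatter of two such steps. This supports carrying the change between the core of compound 1 and the core of compound 2 as a small step, but with both steps within the scatter it does not show that the change shifts the number on either core, and two cores say nothing about a third.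

Open, as far as these compounds go, is how other groups at this place would read, such as an amine, a carboxylic acid or a nitrile.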